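From a Thiourea-Bearing Lead to a Dimethylaminoethyl Carbamoyl Analogue

The source may report more compounds than this note shows. Statements on the series, on what has been measured and on what is new or still open speak of the compounds shown alone.

Compound 1 `CN(c1ccc(N/C(S)=N/c2ccccc2)cc1)c1ccnc(Nc2cccc(CS(C)(=O)=O)c2)n1` gives 6 nM in a functional assay on HUVEC cells (Homo sapiens) for inhibition; on this read-out lower numbers stand for stronger inhibition and higher numbers for weaker inhibition.
Compound 2 `CCNC(=O)Nc1ccc(N(C)c2ccnc(Nc3ccc(CS(C)(=O)=O)cc3)n2)cc1` gives 27 nM in this assay.

Compound 1 stands at the lowest of the two numbers; compound 2 lies beyond the usual scatter above it. Compound 3 `CN(C)CCNC(=O)Nc1ccc(N(C)c2ccnc(Nc3cccc(CS(C)(=O)=O)c3)n2)cc1` has not yet been measured. It differs from compound 1 in one place: a group of 8 heavy atoms (5 carbon, 2 nitrogen, 1 oxygen; no ring) in place of a group of 9 heavy atoms (7 carbon, 1 nitrogen, 1 sulfur; one six-membered aromatic ring of carbon only), on a nitrogen on an aromatic ring. Within the data shown here, no step between measured compounds matches this change, so only the two values shown can guide an expectation. Compound 2 gives 27 nM, and compound 3 is expected to land closer to it than to compound 1. A moderate weakening is expected, as a 2.5-fold higher number from compound 1 to compound 3 (0.40 log units; beyond the scatter). Compound 3 is estimated at 15 nM, within 5 nM to 50 nM.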

Compound 3, half-maximal inhibitory concentration: 530 nM
Estimate against measurement, compound 3: 35-fold (1.55 log units) below; the measured number lies above the stated range.
By their numbers in this assay, from the lowest: compound 1; then compound 2; then compound 3.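

In this assay, the step to (2-(dimethylamino)ethyl)carbamoyl on this nitrogen is an 88-fold higher number from compound 1 to compound 3 (1.95 log units; beyond the scatter), so this position does not accept every group of similar size. The two groups have close heavy-atom counts and the same hydrogen-bond donor count, yet the values lie far apart. Nothing measured here explains this weakening.

On these data alone, it remains open whether the weakening goes with losing the six-membered aromatic ring or with gaining the dimethylamino end of the chain. A phenylcarbamoyl group or a (2-methoxyethyl)carbamoyl group on this nitrogen would help tell these apart.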